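Chloro in Place of Hydrogen: Notes on Compounds 1 to 4

The source may hold more compounds than are shown below. What is called first, only, known or untested is meant among the compounds shown, and "the series" means these compounds.

Compound 1 `CC(=O)OC/C(=C\C1CCCCC1)C(=O)c1ccccc1` gives 21000 nM.
Compound 2 `CC(=O)OC/C(=C\C1CCCCC1)C(=O)c1ccc(Cl)cc1` gives 31000 nM.
Compound 3 `CC(=O)OC/C(=C/c1ccccc1Cl)C(=O)c1ccccc1` gives 21000 nM.

All three were run in a functional assay on HBL-100 cells (Homo sapiens) for inhibition, read by sulforhodamine B assay, with a stated time of 48 h; a lower number here means a stronger inhibitor of growth, a higher number a weaker inhibitor of growth. Compound 2 differs from compound 1 by chloro in place of hydrogen on an aromatic carbon; the resulting step is a 1.5-fold higher number from compound 1 to compound 2 (0.17 log units; within the scatter). Compound 3 differs from compound 1 in its core, and that difference is not broken down here. Compound 3 and compound 1 give the same number at the digits shown, and compound 2 lies within the scatter of both.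

Compound 4 `CC(=O)OC/C(=C/c1ccc(Cl)cc1Cl)C(=O)c1ccccc1` is not yet measured. It differs from compound 3 by chloro in place of hydrogen on an aromatic carbon. This is the same kind of change as from compound 1 to compound 2, but not the same: here the entering chloro is meta to a chloro group, which the earlier place lacks. Because the earlier step of a 1.5-fold higher number from compound 1 to compound 2 (0.17 log units; within the scatter) stayed within the scatter, a step of similar size is expected, a 1.2-fold higher number from compound 3 to compound 4 (0.08 log units; within the scatter). The expected value for compound 4 in this assay is 25000 nM, with a range from 10000 nM to 60000 nM.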

Compound 4, concentration for 50% growth inhibition: 23000 nM
Compound 4: middle estimate off by 1.1-fold (0.04 log units), on the high side, and the stated range covers the measured number.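

In this assay, chloro in place of hydrogen on an aromatic carbon gives a 1.1-fold higher number from compound 3 to compound 4 (0.04 log units; within the scatter), so on this core the number stays within the scatter. This does not show that the change would behave alike on cores beyond these two, or at other places on the ring, and compound 4 also differs from compound 2 in that its entering chloro is meta to a chloro group. The two cores show no difference in the size of the step, and with steps this small the comparison shows only that the change is carried without a clear shift: the same change on two cores in this assay, a 1.5-fold higher number (0.17 log units; within the scatter) from compound 1 to compound 2 and a 1.1-fold higher number (0.04 log units; within the scatter) from compound 3 to compound 4, 1.3-fold (0.13 log units) apart, within the scatter of two such steps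

What the compounds shown leave open is how a group other than chloro, such as an amine or a carboxylic acid, would behave at the same place. Also open, on these data alone, is whether any replacement of the acetate ester, such as a longer chain, would move the number beyond the scatter.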